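Methyl to Ethyl on the Aromatic Nitrogen of Compound 2

The source may hold more compounds than are shown below. What is called first, only, known or untested is meant among the compounds shown, and "the series" means these compounds.

Measured compounds:
compound 1, `Cn1cccc1-c1ccccc1NCC1=NCCN1`: 103%
compound 2, `Cn1cc(-c2ccccc2NCC2=NCCN2)cn1`: 39%
compound 3, `Cn1ncnc1-c1ccccc1NCC1=NCCN1`: 91%

In a functional assay with Alpha-1A adrenergic receptor (Homo sapiens) as the target, read by calcium flux (a lower number here means a smaller maximal response, a higher number a larger maximal response), compound 2 stands lowest of the three numbers. The step of a number 52 percentage points higher from compound 2 to compound 3 (beyond the scatter) and the step of a number 64 percentage points lower from compound 1 to compound 2 (beyond the scatter) both leave it well apart from the other two, and each of those steps swaps the whole five-membered ring on the aromatic carbon, not a substituent on it. Compound 4, `CCn1cc(-c2ccccc2NCC2=NCCN2)cn1`, is the unmeasured compound. It differs from compound 2 by methyl in place of hydrogen on a saturated chain carbon bound to an aromatic nitrogen.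

Within the data shown here, none of the measured steps bears on this change: a number 64 percentage points lower from compound 1 to compound 2 (beyond the scatter) and a number 12 percentage points lower from compound 1 to compound 3 (beyond the scatter) each exchange one heteroaryl ring for another, and the change from compound 2 to compound 4 keeps the 1-methyl-1H-pyrazol-4-yl ring type and only lengthens the chain on its nitrogen. Among the measured compounds shown here, with no step of this kind measured, the expectation is a step of no more than the scatter in this assay, in either direction.

Compound 4 is therefore expected to give 40% in this assay, in a range from 20% to 65%. This estimate means an expected step of a number 1 percentage points higher from compound 2 to compound 4 (within the scatter).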

Compound 4, largest response reached (reported as maximal response), in percent of the reference or control that the assay uses: 0%
For compound 4 the middle estimate is 40 percentage points above the measured one, outside the stated range (below it).
By their numbers in this assay, from the lowest: compound 4; then compound 2; then compound 3; then compound 1.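

The step of a number 39 percentage points lower from compound 2 to compound 4 (beyond the scatter) shows that in this assay the maximal response depends on the group on the ring nitrogen as well as on the choice of ring. Until now, every difference among the compounds had come from exchanging one five-membered ring for another, so nothing had tested this position on its own. Here the 1-methyl-1H-pyrazol-4-yl ring type stays in place, and a single methyl on a saturated chain carbon bound to an aromatic nitrogen, the change from methyl to ethyl, is enough to take compound 4 to 0%, a large step from one added carbon. No evidence at hand gives a reason for this step.

The compounds shown leave open how the response runs along this position: whether the unsubstituted ring nitrogen, a propyl chain, an isopropyl group or a cyclopropyl ring would sit with compound 2 or with compound 4. They also leave open whether an ethyl group in place of the methyl on the ring of compound 1 or compound 3 would bring a step of similar size, or whether this step belongs to the pyrazole ring of compound 2 alone.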